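The compounds below may be only part of what the source reports. "The series", "measured", "known", "first", "only" and "open" are said of these compounds alone.

Compound 1 `C=C1[C@@H](O)[C@H](n2cnc3c(O)nc(N)nc32)O[C@@H]1CO`: > 200000 nM, a limit
Compound 2 `C=C1[C@@H](O)[C@H](n2cnc3c(N(C)C)nc(N)nc32)O[C@@H]1CO`: > 500000 nM, a limit
Compound 3 `C=C1[C@@H](O)[C@H](n2cnc3c(S)nc(N)nc32)O[C@@H]1CO`: 12000 nM

All three were tested in a functional assay on MT4 cells (Homo sapiens) for inhibition; on this read-out higher numbers stand for weaker inhibition and lower numbers for stronger inhibition. Among the compounds with values here, compound 3 is the only one with an actual number, as the other two values are limits. Compound 4 `C=C1[C@@H](O)[C@H](n2cnc3c(SC)nc(N)nc32)O[C@@H]1CO` differs from compound 3 by one change, methyl in place of hydrogen on a sulfur, turning sulfanyl into methylsulfanyl. Within the data shown here, two measured steps bear on this, both large: an at least 16-fold lower number from compound 1 to compound 3 (1.22 log units; beyond the scatter) and an at least 41-fold lower number from compound 2 to compound 3 (1.61 log units; beyond the scatter). Each of them introduces sulfanyl, and methylation alters that same group, so part of this advantage may be lost. The expected step is a 3.3-fold higher number from compound 3 to compound 4 (0.52 log units; beyond the scatter), toward weaker inhibition. For compound 4 the estimate is 40000 nM, with an expected range from 8000 nM to 200000 nM.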

Compound 4, half-maximal inhibitory concentration: > 500000 nM
Compound 4: no number, only a limit; the forecaster's own chance of this, stated with the estimate: 25%; middle value at least 12-fold (1.09 log units) from the limit.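

In this assay, methyl in place of hydrogen on the sulfur gives an at least 41-fold higher number from compound 3 to compound 4 (1.61 log units; beyond the scatter), so the gain seen with sulfanyl depends on that hydrogen and does not survive this single added methyl. From the compounds shown here alone, the value of compound 4 is a limit, so the full size of this loss stays unknown: the limit of > 500000 nM in this assay, at which 2 of the 4 values shown sit. The steps from compound 1 and compound 2 to compound 4 cannot be read, since both ends are limits.

Still open, going by these compounds, is whether an ethyl chain on the sulfur would behave like methyl. On these data alone, a plain amino group on the aromatic carbon also remains untested here against sulfanyl.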